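The compounds below may be only part of what the source reports. "The series", "measured", "known", "first", "only" and "open" are said of these compounds alone.

Compound 1 `COc1ccc(NC(=O)[C@@H]2Cc3ccc(OCC(=O)NO)cc3CN2C(=O)[C@@H]2CCCN2C(=O)OC(C)(C)C)cc1` gives 212 nM in an assay on isolated protein for inhibition of histone deacetylase 8 (Homo sapiens), read by fluorescence, with a stated time of 30 min; a lower number here means a stronger inhibitor, a higher number a weaker inhibitor; compound 2 `CC[C@H](C)[C@H](N)C(=O)N1Cc2cc(OCC(=O)NO)ccc2C[C@H]1C(=O)Nc1ccc(OC)cc1` gives 1040 nM.

Among the measured compounds shown here, compound 2 stands at the higher of the two numbers so far. Compound 3 `COc1ccc(NC(=O)[C@@H]2Cc3ccc(OCC(=O)NO)cc3CN2C(=O)[C@@H](N)C(C)C)cc1` differs from compound 2 by hydrogen in place of methyl on a saturated chain carbon, three bonds along the chain from an amine nitrogen and a carbonyl carbon. For the measured compounds named here, the only measured step, a 4.9-fold higher number from compound 1 to compound 2 (0.69 log units; beyond the scatter), concerns a different group, so no step bears directly on this change. Going by the values given here, for compound 3 the expected step is a 1.1-fold higher number from compound 2 to compound 3 (0.02 log units; within the scatter), nothing beyond the scatter, as no measured step argues otherwise. Compound 3 is therefore estimated at 1100 nM in this assay, within a range of 500 nM to 2500 nM.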

Compound 3, half-maximal inhibitory concentration: 1020 nM
Estimate against measurement, compound 3: 1.1-fold (0.03 log units) above; the range from low to high includes it.
By their numbers in this assay, from the lowest: compound 1; then compounds 3 and 2 (each within the scatter of the next).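

In this assay, the change from sec-butyl to isopropyl gives a 1.0-fold lower number from compound 2 to compound 3 (0.01 log units; within the scatter), so these two groups cannot be told apart at this position. The 1-(tert-butoxycarbonyl)pyrrolidin-2-yl group now also holds its advantage over 1-amino-2-methylpropyl, with a 4.8-fold higher number from compound 1 to compound 3 (0.68 log units; beyond the scatter), so the advantage seen against 1-amino-2-methylbutyl does not rest on that one methyl. Nothing measured here explains either step.

The compounds shown leave open how a phenyl ring or a carboxylic acid in place of the isopropyl would read in this assay. They also leave open whether the tert-butoxycarbonyl group or the pyrrolidine ring carries the difference from compound 1.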